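A few compounds are considered here, and "the series" means these few. Any claim that something is new, unique, unknown or untested is made for them only; others in the source may bear on it.

Working notes on the series.

Compound 1 `Cc1csc(-c2cc(NC(=O)c3ccc(OCc4ccccn4)cc3)c(C)cc2C)n1` is the reference point. For the measured compounds named here, in an ADME assay on microsomes from liver (Rattus norvegicus) for metabolic stability (a lower number here means slower removal, a higher number faster removal of the compound), compound 1 gives 147 mL.min-1.g-1, the second highest of the three numbers measured so far. Compound 2 `Cc1cc(C)c(-c2c(C)nn(C)c2C)cc1NC(=O)c1ccc(OCc2ccccn2)cc1` gives 271 mL.min-1.g-1, and compound 3 `Cc1cc(C)c(-c2cccnc2)cc1NC(=O)c1ccc(OCc2ccccn2)cc1` gives 78 mL.min-1.g-1. The step of a 1.8-fold higher number from compound 1 to compound 2 (0.27 log units; within the scatter) and the step of a 1.9-fold lower number from compound 1 to compound 3 (0.28 log units; within the scatter) both stay within the scatter of repeated measurements, so neither shows a real change from compound 1. Going by the values given here, only the step of a 3.5-fold lower number from compound 2 to compound 3 (0.54 log units; beyond the scatter) goes beyond the scatter, and it is modest.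

Compound 4 `Cc1cc(C)c(-c2ccc(N)cn2)cc1NC(=O)c1ccc(OCc2ccccn2)cc1` is the next compound to be measured. It differs from compound 1 by 5-aminopyridin-2-yl in place of 4-methyl-1,3-thiazol-2-yl on an aromatic carbon. Among the compounds with values here, the closest precedent among the measured steps is the exchange of the same four-methyl-thiazolyl group for pyridin-3-yl, recorded as a 1.9-fold lower number from compound 1 to compound 3 (0.28 log units; within the scatter), a six-membered ring with one hetero atom in place of the five-membered ring, which did not move the number beyond the scatter. Within the data shown here, no measured step covers the amino group that enters with 5-aminopyridin-2-yl, so there is nothing to ground a larger shift.

On that basis the step of a 1.5-fold lower number from compound 1 to compound 4 (0.19 log units; within the scatter) is expected to be small, leaning toward the side seen with compound 3 but not clearly beyond the scatter. Compound 4 is therefore estimated at 95 mL.min-1.g-1, with a range from 40 mL.min-1.g-1 to 220 mL.min-1.g-1.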

Compound 4, intrinsic clearance in microsomes: 32 mL.min-1.g-1
Compound 4: the middle estimate sits 3.0-fold (0.47 log units) above what was measured; measured number below the stated range.
By their numbers in this assay, from the lowest: compound 4; then compounds 3, 1 and 2 (each within the scatter of the next, the first and the last beyond it).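

In this assay, this position now shows a step clearly beyond the scatter from the reference, a 4.6-fold lower number from compound 1 to compound 4 (0.66 log units; beyond the scatter), with 5-aminopyridin-2-yl in place of 4-methyl-1,3-thiazol-2-yl, whereas the earlier pyridin-3-yl exchange gave only a 1.9-fold lower number from compound 1 to compound 3 (0.28 log units; within the scatter), which stayed within it. For the compounds shown here, the two six-membered aromatic rings are also separated, with a 2.4-fold lower number from compound 3 to compound 4 (0.39 log units; beyond the scatter), and the gap to the trimethylpyrazolyl compound reaches an 8.5-fold lower number from compound 2 to compound 4 (0.93 log units; beyond the scatter), so compound 4 stands beyond the scatter from all three earlier compounds and the span at this one position is wider than the earlier compounds showed. The groups at this position differ in more than the amino group, since the ring is also joined through a different carbon, and nothing in the available data accounts for the lower number.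

The compounds shown leave open whether the step follows the amino group or the pyridin-2-yl attachment, which a plain pyridin-2-yl group would help to separate. As far as these compounds go, how a 5-methoxypyridin-2-yl or 5-(dimethylamino)pyridin-2-yl group would compare at this position also remains open.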